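Isoxazole-linked indole series: cytotoxicity in Calu-3 cells

A few compounds are considered here, and "the series" means these few. Any claim that something is new, unique, unknown or untested is made for them only; others in the source may bear on it.

Measured so far, in a functional assay on Calu-3 cells (Homo sapiens) for cytotoxicity, read by WST assay, with a stated time of 72 h; a higher number here means a weaker inhibitor, a lower number a stronger inhibitor:
compound 1 `Cn1c(-c2cc(-c3cccc(F)c3)on2)cc2ccccc21` gives > 100000 nM, a limit of the assay.
compound 2 `Cn1c(-c2cc(-c3ccc(F)cc3)no2)cc2ccccc21` gives > 100000 nM, also a limit.
compound 3 `COc1ccc(-c2cc(-c3cc4ccccc4n3C)on2)cc1` gives > 100000 nM, again a limit.

Among the compounds with values here, all three values sit at the limit of > 100000 nM in this assay, at which 3 of the 3 values shown sit, so no compound can be ranked against another. Compound 1 and compound 2 share the same atoms joined differently; the difference between the two cores is not broken down here. From compound 2 to compound 3 the change is methoxy in place of fluoro on an aromatic carbon, and the step is a step that the two limits leave unreadable from compound 2 to compound 3.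

Compound 4 `COc1cccc(-c2cc(-c3cc4ccccc4n3C)no2)c1` is not yet measured. Relative to compound 1 it carries methoxy in place of fluoro on an aromatic carbon, the same kind of change as from compound 2 to compound 3, but meta to a large group rather than para to a large group. Since compound 1 sits at the limit > 100000 nM and the comparable step that the two limits leave unreadable from compound 2 to compound 3 remained unreadable, compound 4 is expected to remain at or near the limit in this assay, an expected step that the limit leaves unreadable from compound 1 to compound 4. The estimate for compound 4 is 150000 nM, between 50000 nM and 500000 nM.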

Compound 4, half-maximal inhibitory concentration: 17300 nM
Compound 4: middle estimate off by 8.7-fold (0.94 log units), on the high side; the whole stated range lies above it.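

In this assay, methoxy in place of fluoro on an aromatic carbon, meta to a large group, gives an at least 5.7-fold lower number from compound 1 to compound 4 (0.76 log units; beyond the scatter); the true size of this step is not fixed, as compound 1 stands at a limit. The same kind of change, para to a large group on the core of compound 2, cannot be read, and neither can the other steps among the compounds at the limit, because both ends of each sit there: the limit of > 100000 nM in this assay, at which 3 of the 4 values shown sit.

The change therefore lowers the number on the core of compound 1 only, and whether it carries over to the core of compound 2 is not shown.

Open, on these data alone, is whether an amine, a carboxylic acid or a longer chain in place of the methoxy would lower the number further or return it to the limit. Also open, as far as these compounds go, is how methoxy reads para to a large group on the core of compound 1.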